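From a Thiophene Sulfonamide to a Tolyl Sulfonamide

The source may hold more compounds than are shown below. What is called first, only, known or untested is meant among the compounds shown, and "the series" means these compounds.

Three sulfonamides on a shared core were tested in an assay on cells for inhibition of HSP60/HSP10 (Homo sapiens), with a stated time of 60 min; a higher number here means a weaker inhibitor, a lower number a stronger inhibitor. Compound 1 `O=S(=O)(Nc1ccc(-c2nc3ccccc3o2)cc1)c1cccs1` is the only one of the three that yields a number: in this assay compound 1 gives 63000 nM. Compound 2 `O=S(=O)(Nc1ccc2oc(-c3ccccc3)nc2c1)c1ccccc1Cl` returns only a limit of the assay, > 100000 nM. Compound 3 `Cc1cccc(S(=O)(=O)Nc2ccc3oc(-c4ccccc4)nc3c2)c1` likewise returns a limit, > 100000 nM. The step from compound 2 to compound 3 is a step that the two limits leave unreadable from compound 2 to compound 3, so it offers no guidance on how a change at the sulfonyl sulfur shifts potency. Compound 4 `Cc1ccc(S(=O)(=O)Nc2ccc(-c3nc4ccccc4o3)cc2)cc1` differs from compound 1 by 4-methylphenyl in place of thiophen-2-yl on a sulfonyl sulfur. Within the data shown here, no measured step bears directly on this change; the only step measured at a sulfonyl sulfur is unreadable, and the limit of > 100000 nM in this assay, at which 2 of the 3 values shown sit, shows how close this series sits to the edge of the assay, with compound 1 itself standing near that edge. Compound 4 is therefore expected to remain a weak inhibitor, with an estimate of 80000 nM (range 30000 nM to 200000 nM) and a real chance that only a limit is reported. The expected step is a 1.3-fold higher number from compound 1 to compound 4 (0.10 log units; within the scatter), no more than the scatter.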

Compound 4, half-maximal inhibitory concentration: > 100000 nM
Compound 4 ended at the assay's limit; the forecaster's own chance of this, stated with the estimate: 40%; middle value at least 1.2-fold (0.09 log units) from the limit.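

In this assay, among these compounds, the change to 4-methylphenyl in place of thiophen-2-yl on a sulfonyl sulfur gives an at least 1.5-fold higher number from compound 1 to compound 4 (0.20 log units; that floor lies within the scatter) and is the first step at this sulfur that can be read at all. Only a floor is known for this step, and since that floor lies within the scatter, the result does not show a true loss on leaving thiophen-2-yl, though the real gap may be larger. Among the compounds shown here, compound 4 adds a further limit, leaving compound 1 as the only compound with a number and most of the series at the same limit: the limit of > 100000 nM in this assay, at which 3 of the 4 values shown sit. As far as these compounds go, whether thiophen-2-yl itself matters remains open, and a furan-2-yl or an unsubstituted phenyl on the sulfonyl sulfur would bear on that. Also open, from the compounds shown here alone, is whether any group at this sulfur can give a clearly lower number than compound 1 does.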